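Removing the Ethyl and Shortening the Piperazine Linker

The source may hold more compounds than are shown below. What is called first, only, known or untested is meant among the compounds shown, and "the series" means these compounds.

Among the measured compounds shown here, compound 3 `CCN1CCN(CCCN(C[C@H]2Cc3ccccc3CN2)[C@H]2CCCc3cccnc32)CC1` gives 33 nM in a functional assay on CCRF-CEM cells for antagonist activity at C-X-C chemokine receptor type 4 (Homo sapiens), read by calcium flux, with stated times of 25 min and 90 s (a higher number here means a weaker inhibitor, a lower number a stronger inhibitor), and stands second highest among the values measured so far. Compound 2 `c1ccc2c(c1)CN[C@@H](CN(CCCN1CCNCC1)[C@H]1CCCc3cccnc31)C2` gives 17 nM and compound 1 `c1ccc2c(c1)CN[C@@H](CN(CC1CCNCC1)[C@H]1CCCc3cccnc31)C2` gives 65 nM; both sit within the scatter of compound 3, so no order among the three is secure. Compound 4 `c1ccc2c(c1)CN[C@@H](CN(CCN1CCNCC1)[C@H]1CCCc3cccnc31)C2` has not yet been measured. The change from compound 3 is piperazin-1-yl in place of (4-ethylpiperazin-1-yl)methyl on a saturated chain carbon, two bonds along the chain from an amine nitrogen. Two kinds of measured step bear on it. The step of a 1.9-fold higher number from compound 2 to compound 3 (0.29 log units; within the scatter) covers the ethyl on the ring nitrogen, and its reverse would nudge the number slightly down. The steps of a 3.8-fold lower number from compound 1 to compound 2 (0.58 log units; beyond the scatter) and a 2.0-fold lower number from compound 1 to compound 3 (0.29 log units; within the scatter) show that piperazine-bearing chains of either kind give lower numbers than piperidin-4-yl. For the measured compounds named here, no measured step covers shortening the chain by one carbon, so that part is open. The expected step is a 1.3-fold lower number from compound 3 to compound 4 (0.12 log units; within the scatter), within the scatter. The estimate for compound 4 is 25 nM, with a range from 10 nM to 60 nM.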

Compound 4, half-maximal inhibitory concentration: 553 nM
Compound 4: the middle estimate sits 22-fold (1.34 log units) below what was measured; the whole stated range lies below it.
By their numbers in this assay, from the lowest: compounds 2, 3 and 1 (each within the scatter of the next, the first and the last beyond it); then compound 4.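

In this assay, the length of the chain carrying the piperazine proves decisive at this position, with the step of a 33-fold higher number from compound 2 to compound 4 (1.51 log units; beyond the scatter) isolating the change from (piperazin-1-yl)methyl to piperazin-1-yl on the saturated chain carbon. The full change including the ethyl, 3-(4-ethylpiperazin-1-yl)propyl to 2-(piperazin-1-yl)ethyl, gives a 17-fold higher number from compound 3 to compound 4 (1.22 log units; beyond the scatter) and is of the same large order, whereas the ethyl alone stayed within the scatter. A piperazine on the chain therefore does not by itself give a lower number than piperidin-4-yl: compounds 2 and 1 fit that earlier reading only in part, and the step of an 8.5-fold higher number from compound 1 to compound 4 (0.93 log units; beyond the scatter) goes against it.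

Still open, on these data alone, is whether a longer chain ending in piperazine, or an ethyl on the ring nitrogen of compound 4, would shift the number. Nothing available here explains the loss on shortening the chain.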